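A few compounds are considered here, and "the series" means these few. Any claim that something is new, unique, unknown or untested is made for them only; others in the source may bear on it.

Working notes on the series, read in a functional assay on HCT-116 cells (Homo sapiens) for cytotoxicity, read by MTT assay, with a stated time of 72 h; on this read-out lower numbers stand for stronger inhibition and higher numbers for weaker inhibition. Compound 1 `O=C1c2c[n+]([O-])c3ccccc3c2C(=O)c2c1c1ccccc1n2Cc1cn(CC(O)CO)nn1` gives 250 nM, compound 2 `CN1CCN(CCCn2c3c(c4ccccc42)C(=O)c2c[n+]([O-])c4ccccc4c2C3=O)CC1` gives 560 nM, and compound 3 `CN1CCN(CCCCCCn2c3c(c4ccccc42)C(=O)c2c[n+]([O-])c4ccccc4c2C3=O)CC1` gives 2900 nM, the highest number of the three.

Still unmeasured is compound 4 `CN(C)CCCCn1c2c(c3ccccc31)C(=O)c1c[n+]([O-])c3ccccc3c1C2=O`. Its difference from compound 3 is dimethylamino in place of 2-(4-methylpiperazin-1-yl)ethyl on a saturated chain carbon, four bonds along the chain from an aromatic nitrogen.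

Within the data shown here, no measured step makes this exact swap, and no measured compound carries a dimethylamino group. The closest guide is a 5.2-fold higher number from compound 2 to compound 3 (0.71 log units; beyond the scatter), where the 4-methylpiperazin-1-yl group is kept and the chain is extended by 3-(4-methylpiperazin-1-yl)propyl in place of 4-methylpiperazin-1-yl. The change to compound 4 runs partly back along that step. The step of a 12-fold higher number from compound 1 to compound 3 (1.06 log units; beyond the scatter) gives the full span of the series, and a 2.2-fold higher number from compound 1 to compound 2 (0.35 log units; beyond the scatter) bears less directly.

The expected step is a 2.9-fold lower number from compound 3 to compound 4 (0.46 log units; beyond the scatter), modest and toward a lower number in this assay. For compound 4 the estimated value is 1000 nM, with an expected range of 350 nM to 2900 nM.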

Compound 4, half-maximal inhibitory concentration: 450 nM
Estimate against measurement, compound 4: 2.2-fold (0.35 log units) above; the range from low to high includes it.
By their numbers in this assay, from the lowest: compounds 1, 4 and 2 (each within the scatter of the next, the first and the last beyond it); then compound 3.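

In this assay, the change to dimethylamino on a saturated chain carbon, four bonds along the chain from an aromatic nitrogen, gives a 6.4-fold lower number from compound 3 to compound 4 (0.81 log units; beyond the scatter) and shows that the high number of compound 3 does not extend to this shorter amine side chain. The comparisons with the other two compounds, a 1.2-fold lower number from compound 2 to compound 4 (0.09 log units; within the scatter) and a 1.8-fold higher number from compound 1 to compound 4 (0.26 log units; within the scatter), are both within the scatter, so compound 4 cannot be ordered against either, although compound 1 and compound 2 remain beyond the scatter of each other. No measurement available here accounts for these differences.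

Compound 3 and compound 4 differ in both chain length and end group, so the contribution of each remains unresolved. Dimethylamino on the longer chain of compound 3, or 4-methylpiperazin-1-yl on the chain of compound 4, would separate them, and a morpholine or primary amine at the chain end remains open.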